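The source may report more compounds than this note shows. Statements on the series, on what has been measured and on what is new or still open speak of the compounds shown alone.

Working notes on the series. Compound 1 `CC(O)(CSc1ccc(S(F)(F)(F)(F)F)cc1)C(=O)Nc1cccc(S(F)(F)(F)(F)F)c1` is the thioether bearing the larger substituent on both rings; in a functional assay on VCaP cells (Homo sapiens) for antiproliferative activity, read by propidium iodide staining, with a stated time of 96 h (on this read-out higher numbers stand for weaker inhibition and lower numbers for stronger inhibition), compound 1 gives 24100 nM. Compound 2 `CC(O)(CSc1ccc(F)cc1)C(=O)Nc1cccc(S(F)(F)(F)(F)F)c1` differs from it only by one fluorine atom in place of a group of 6 heavy atoms (5 fluorine, 1 sulfur; no ring), on an aromatic carbon. In this assay compound 2 gives 21900 nM, and the step is a 1.1-fold lower number from compound 1 to compound 2 (0.04 log units; within the scatter), so the exchange left the read-out essentially where it was.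

Compound 3 `CC(O)(CS(=O)(=O)c1ccc(S(F)(F)(F)(F)F)cc1)C(=O)Nc1ccc(S(F)(F)(F)(F)F)cc1` belongs to a second core; the difference between the two cores is not broken down here. In this assay compound 3 gives 15700 nM. Its gaps to compound 1 and compound 2 are both within the scatter, so no order among the three measured compounds can be read from these numbers.

Compound 4 `CC(O)(CS(=O)(=O)c1ccc(F)cc1)C(=O)Nc1ccc(S(F)(F)(F)(F)F)cc1` has not been measured. It differs from compound 3 by one fluorine atom in place of a group of 6 heavy atoms (5 fluorine, 1 sulfur; no ring), on an aromatic carbon, the same change that was made from compound 1 to compound 2; among the four compounds the change occurs twice. Because the earlier instance gave a 1.1-fold lower number from compound 1 to compound 2 (0.04 log units; within the scatter), the step from compound 3 to compound 4 in this assay is expected to be about a 1.1-fold lower number from compound 3 to compound 4 (0.05 log units; within the scatter). That expectation rests on a single measured step and on the unbroken-down difference between the cores, so it is held loosely. Compound 4 is accordingly estimated at 14000 nM, with a plausible range from 7000 nM to 30000 nM.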

Compound 4, half-maximal inhibitory concentration: 34200 nM
For compound 4 the middle estimate is 2.4-fold (0.39 log units) below the measured one; measured number above the stated range.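

In this assay, replacing the group of 6 heavy atoms with fluoro on the second core gives a 2.2-fold higher number from compound 3 to compound 4 (0.34 log units; beyond the scatter), a modest step, whereas the same exchange on the first core left the read-out unchanged within the scatter. Although the new step alone lies beyond the scatter, the comparison of the two instances does not establish that they differ: the same change on two cores in this assay, a 1.1-fold lower number (0.04 log units; within the scatter) from compound 1 to compound 2 and a 2.2-fold higher number (0.34 log units; beyond the scatter) from compound 3 to compound 4, 2.4-fold (0.38 log units) apart, within the scatter of two such steps. Among the compounds shown here, the series therefore shows neither that the change carries over from one core to the other with the same effect nor that its effect depends on the core, as each core offers only one measured pair.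

The compounds shown leave open how the two cores themselves compare, as no measured pair isolates that difference in one place. They also leave open whether a trifluoromethyl group or a nitrile, in the same place on the aromatic ring, would follow either measured step on these cores.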